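Swapping the dichlorophenyl ketone for a dimethoxyphenyl one

The compounds below may be only part of what the source reports. "The series", "measured", "known", "first", "only" and "open" are said of these compounds alone.

Compound 1, `COc1cc(-c2cc(/C=C/C(=O)c3ccc(Cl)c(Cl)c3)[nH]n2)cc(OC)c1OC`, gives 7220 nM in a functional assay on MDA-MB-468 cells (Homo sapiens) for inhibition, read by sulforhodamine B assay, with a stated time of 48 h; on this read-out lower numbers stand for stronger inhibition of growth and higher numbers for weaker inhibition of growth.
Compound 2, `COc1ccc(-c2cc(/C=C/C(=O)c3ccc(N)cc3)[nH]n2)cc1OC`, gives 3480 nM.
Compound 3, `COc1ccc(-c2cc(/C=C/C(=O)c3cc(OC)c(OC)c(OC)c3)[nH]n2)cc1OC`, gives 3270 nM.

Among these three measured compounds, compound 1 stands at the highest number, with both compound 2 and compound 3 coming in beyond the scatter below it; the two lower values sit within the scatter of each other and are not ordered here. All three share a core carrying an aryl ketone, and the measured differences concern the aryl group on that carbonyl.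

Compound 4, `COc1ccc(C(=O)/C=C/c2cc(-c3cc(OC)c(OC)c(OC)c3)n[nH]2)cc1OC`, is the next compound to be measured. Relative to compound 1 it differs in one place: 3,4-dimethoxyphenyl in place of 3,4-dichlorophenyl on a carbonyl carbon. Among the compounds with values here, no measured pair isolates this exact exchange, so the expectation rests only on compound 1 at 7220 nM and on compound 2 and compound 3, whose oxygen- or nitrogen-bearing aryl ketones give lower numbers than compound 1. On that basis the step from compound 1 to compound 4 is expected to lower the number modestly, a 1.9-fold lower number from compound 1 to compound 4 (0.28 log units; within the scatter), a step that may not clear the scatter. Compound 4 is therefore estimated at 3800 nM, with a range from 1500 nM to 9500 nM.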

Compound 4, concentration for total growth inhibition: 2180 nM
Compound 4: middle estimate off by 1.7-fold (0.24 log units), on the high side, and the stated range covers the measured number.
By their numbers in this assay, from the lowest: compounds 4, 3 and 2 (each within the scatter of the next); then compound 1.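

In this assay, within the data shown here, putting 3,4-dimethoxyphenyl in place of 3,4-dichlorophenyl on a carbonyl carbon gives a 3.3-fold lower number from compound 1 to compound 4 (0.52 log units; beyond the scatter), the first comparison at this position between compounds that differ in one place only. Among these compounds, compound 2 and compound 3 differ from compound 1 in more than one place, so only this step shows that the aryl group on the carbonyl can, with the rest of compound 1 held fixed, move the number beyond the scatter. No measurement shown here accounts for the size or direction of this step.

Going by these compounds, whether the change follows from the two methoxy groups entering or the two chlorine atoms leaving remains open, and an unsubstituted phenyl on the same carbonyl carbon would bear on that question. Also open, on these data alone, is whether the same exchange gives a similar step on the remainder of compound 3.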